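The source may report more compounds than this note shows. Statements on the series, on what has been measured and on what is new or still open speak of the compounds shown alone.

Compound 1 `ClCc1ccccc1Cn1cnc2c(Cl)nc(Cl)nc21` and compound 2 `ClCc1cccc(Cn2cnc3c(Cl)nc(Cl)nc32)c1` are built from the same atoms joined differently; the difference between the two cores is not broken down here. In a functional assay on SK-MEL-2 cells (Homo sapiens) for cytotoxicity, read by sulforhodamine B assay, with a stated time of 48 h (a lower number here means a stronger inhibitor of growth, a higher number a weaker inhibitor of growth), compound 1 gives 2180 nM, and compound 2 gives 1990 nM. These two numbers lie within the usual scatter of each other, so neither compound can be set apart from the other on this read-out.

Compound 3 `Nc1nc(Cl)c2ncn(Cc3ccccc3CCl)c2n1` is compound 1 with a single change: amino in place of chloro on an aromatic carbon. That change moved the result by an 8.5-fold higher number from compound 1 to compound 3 (0.93 log units; beyond the scatter), and in this assay compound 3 gives 18600 nM. Among the three measured compounds this is the one clearly weaker result.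

Compound 4 `Nc1nc(Cl)c2ncn(Cc3cccc(CCl)c3)c2n1` has not yet been measured. It stands to compound 2 as compound 3 stands to compound 1: amino in place of chloro on an aromatic carbon. The description of where the change sits is the same word for word for both pairs, so this is the same change made on the core of compound 2. For the measured compounds named here, only one earlier instance of it is known, so the expectation rests on that one pair alone, together with the near-equal results of compound 1 and compound 2. The expected step is an 8.0-fold higher number from compound 2 to compound 4 (0.91 log units; beyond the scatter), set beside the measured 8.5-fold higher number from compound 1 to compound 3 (0.93 log units; beyond the scatter). Compound 4 is estimated at 16000 nM in this assay. The likely range for compound 4 runs from 6000 nM to 40000 nM.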

Compound 4, concentration for 50% growth inhibition: 10700 nM
The estimate for compound 4 lay 1.5-fold (0.17 log units) above the measured number; the measured number falls inside the stated range.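

In this assay, the same swap of amino in place of chloro on an aromatic carbon that weakened compound 1 also weakens growth inhibition on the second core, with a 5.4-fold higher number from compound 2 to compound 4 (0.73 log units; beyond the scatter). Set side by side, the two steps point the same way and cannot be told apart in size: the same change on two cores in this assay, an 8.5-fold higher number (0.93 log units; beyond the scatter) from compound 1 to compound 3 and a 5.4-fold higher number (0.73 log units; beyond the scatter) from compound 2 to compound 4, 1.6-fold (0.20 log units) apart, within the scatter of two such steps. For the compounds shown here, this shows that, across these two pairs, the change carries from one core to the other with much the same loss, but it rests on only two pairs that are built from the same atoms joined differently, in a single cell assay, so it gives no rule for more distant cores or other read-outs, and it does not explain why the amino compounds are weaker.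

The compounds shown leave open how other groups would fare on that same aromatic carbon, such as a methoxy group, a methylamino group or a dimethylamino group, and so whether the loss is tied to amino itself or would follow any replacement of chloro. They also leave open whether the step would hold on a third core, for example one with a longer chain in place of the chloromethyl group of compound 1 and compound 2.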